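Compound 2 to compound 3: replacing 2-methoxyethyl

The source may report more compounds than this note shows. Statements on the series, on what has been measured and on what is new or still open speak of the compounds shown alone.

Measured in a physicochemical assay for solubility, in phosphate buffer, at pH 7.4; on this read-out lower numbers stand for lower solubility and higher numbers for higher solubility:
- Compound 1 `Fc1ccc(Nc2cc(-c3ccnc(Nc4ccc(F)cc4)c3)ccn2)cc1`: < 100 nM (a limit of the assay)
- Compound 2 `COCCC(=O)Nc1cc(-c2ccnc(Nc3ccccc3)c2)ccn1`: 20000 nM

In this assay, going by the values given here, compound 2 holds the only true number so far, 20000 nM. Compound 3 `O=C(Nc1cc(-c2ccnc(Nc3ccccc3)c2)ccn1)c1cccnc1` has pyridin-3-yl in place of 2-methoxyethyl on a carbonyl carbon. Among the compounds with values here, the one measured compound without 2-methoxyethyl, compound 1, stands at < 100 nM, and that value is a limit of the assay. On that single comparison, a fall beyond the usual scatter is expected, and the estimated size is a 4.0-fold lower number from compound 2 to compound 3 (0.60 log units; beyond the scatter). For compound 3 the expected value is 5000 nM, with an estimated range from 1000 nM to 15000 nM.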

Compound 3, solubility: 17000 nM
Compound 3: middle estimate off by 3.4-fold (0.53 log units), on the low side; the whole stated range lies below it.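

Pyridin-3-yl in place of 2-methoxyethyl on a carbonyl carbon gives a 1.2-fold lower number from compound 2 to compound 3 (0.07 log units; within the scatter) in this assay and is the first comparison here that differs in one place only. At this position, a six-membered aromatic ring and an open chain therefore read alike. Nothing at hand accounts for this result.

As far as these compounds go, whether an amine or a carboxylic acid on the same carbonyl carbon, or a longer chain there, would also read alike stays open. So does whether other pyridine isomers would match pyridin-3-yl.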